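The source may hold more compounds than are shown below. What is called first, only, known or untested is meant among the compounds shown, and "the series" means these compounds.

Compound 1 `O=C(/C=C/c1cccc(O)c1)CC(=O)/C=C/c1cccc(O)c1O`: 29000 nM
Compound 2 `O=C(/C=C/c1cc(O)ccc1O)CC(=O)/C=C/c1cccc(O)c1O`: 27000 nM
Compound 3 `O=C(/C=C/c1cccc(O)c1)CC(=O)c1ccc(O)c(O)c1`: 10000 nM

In a functional assay, with a stated time of 30 min (a lower number here means a stronger inhibitor, a higher number a weaker inhibitor), compound 1 gives 29000 nM. Compound 2 differs from it in one place, (hydroxy in place of hydrogen on an aromatic carbon), and the step of a 1.1-fold lower number from compound 1 to compound 2 (0.03 log units; within the scatter), so the two numbers cannot be told apart. Compound 3 gives 10000 nM in this assay, the lowest of the three, and its distance from both compound 1 and compound 2 lies beyond the scatter. The difference between the core of compound 1 and the core of compound 3 is not broken down here. Compound 4 `O=C(/C=C/c1cc(O)ccc1O)CC(=O)c1ccc(O)c(O)c1` has not yet been measured. For the measured compounds named here, it differs from compound 3 by hydroxy in place of hydrogen on an aromatic carbon, the same change at the same place as the one that turned compound 1 into compound 2. Because that earlier step was a 1.1-fold lower number from compound 1 to compound 2 (0.03 log units; within the scatter), the same change on the core of compound 3 is expected to give a step of about a 1.1-fold lower number from compound 3 to compound 4 (0.05 log units; within the scatter), an expectation resting on that single earlier pair alone. Compound 4 is therefore estimated at 9000 nM in this assay, with a range from 4500 nM to 18000 nM.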

Compound 4, half-maximal inhibitory concentration: 82000 nM
For compound 4 the middle estimate is 9.1-fold (0.96 log units) below the measured one; the measured number lies above the stated range.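

In this assay, putting hydroxy in place of hydrogen on the core of compound 3 gives an 8.2-fold higher number from compound 3 to compound 4 (0.91 log units; beyond the scatter), so on this core the change makes a weaker inhibitor. Set beside the earlier pair, the result shows that the size of this step does not carry over from one core to the other: the same change on two cores in this assay, a 1.1-fold lower number (0.03 log units; within the scatter) from compound 1 to compound 2 and an 8.2-fold higher number (0.91 log units; beyond the scatter) from compound 3 to compound 4, 8.8-fold (0.94 log units) apart, beyond the scatter of two such steps

What this shows is that, in this series, a step measured on one core is a poor guide to the same change on another, but two pairs cannot show which difference between the cores matters or how it acts.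

The compounds shown leave open whether the large step on the core of compound 3 belongs to hydroxy itself or would also appear with another group at that place, such as a methoxy group or an amine. They also leave open how the same change would behave on any further core.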